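This account rests on a few compounds, and the source may have more. Where it says the series, first, only, none or still open, it means among the compounds named here.

Measured so far:
- compound 1 `COc1cccc(CCC(=O)Nc2nc3ccccc3c(=O)s2)c1`: 95.3 nM
- compound 2 `COc1cccc(C#CC(=O)Nc2nc3ccccc3c(=O)s2)c1`: 43.7 nM

In an in vitro assay on cells for inhibition of Amine oxidase [flavin-containing] B (Homo sapiens), read by fluorescence and Amplex Red, with stated times of 30 min and 45 min (a higher number here means a weaker inhibitor, a lower number a stronger inhibitor), compound 1 gives 95.3 nM, the highest of the two numbers measured, while compound 2 gives 43.7 nM, a difference the data mark as beyond the usual scatter. Compound 3 `O=C(CCc1ccccc1F)Nc1nc2ccccc2c(=O)s1` is not yet measured. It differs from compound 1 in one place: 2-fluorophenyl in place of 3-methoxyphenyl on a saturated chain carbon, two bonds along the chain from a carbonyl carbon. Within the data shown here, no measured pair shows this change, so nothing in the data fixes its direction; the step from compound 1 to compound 3 is expected to be a 1.3-fold higher number from compound 1 to compound 3 (0.10 log units; within the scatter), that is, little beyond the scatter. Compound 3 is therefore estimated at 120 nM, within a range from 40 nM to 400 nM.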

Compound 3, half-maximal inhibitory concentration: 11.2 nM
Beside the measured number, compound 3's estimate is 11-fold (1.03 log units) above it; measured number outside the range, below it.
By their numbers in this assay, from the lowest: compound 3; then compound 2; then compound 1.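

Putting 2-fluorophenyl in place of 3-methoxyphenyl gives an 8.5-fold lower number from compound 1 to compound 3 (0.93 log units; beyond the scatter) in this assay, so the group on this saturated chain carbon can clearly shift the number. The swap removes the methoxy group and also brings in fluorine at a different ring position, so this one step cannot separate those two changes. Nothing available explains the gain. Still open, as far as these compounds go, is how 2-fluorophenyl would behave on the chain of compound 2. Also open, from the compounds shown here alone, is how an unsubstituted phenyl, a 2-chlorophenyl or a longer chain would compare.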